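Lengthening the side chain of an acrylate ester

A few compounds are considered here, and "the series" means these few. Any claim that something is new, unique, unknown or untested is made for them only; others in the source may bear on it.

In an in vitro assay on BL21-DE3 cells for displacement of a labelled ligand from thyroid hormone receptor beta (Homo sapiens), read by fluorescence polarization (on this read-out higher numbers stand for weaker inhibition and lower numbers for stronger inhibition), the measured compounds gave:
Compound 1 `CCCCCCc1ccc(C(=O)/C=C\C(=O)O)cc1`: 17700 nM
Compound 2 `C=CC(=O)c1ccc(CCCCC)cc1`: 33900 nM
Compound 3 `C=CC(=O)Oc1ccc(CCC)cc1`: 61000 nM

Compound 3 holds the highest of the three numbers in this assay. Its gap to compound 2 lies within the scatter, so the two cannot be ranked, while compound 1 gives a clearly lower number, beyond the scatter. Compound 4 `C=CC(=O)Oc1ccc(CCCCC)cc1` differs from compound 3 in one place: ethyl in place of hydrogen on a saturated chain carbon, three bonds along the chain from an aromatic carbon. Compound 1 and compound 2, which carry the longer chains, show the lower numbers, so a modest lowering is expected from the step from compound 3 to compound 4, about a 1.7-fold lower number from compound 3 to compound 4 (0.24 log units; within the scatter). Compound 4 is therefore estimated at 35000 nM in this assay, in a range from 15000 nM to 80000 nM.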

Compound 4, half-maximal inhibitory concentration: 55800 nM
For compound 4 the middle estimate is 1.6-fold (0.20 log units) below the measured one; low and high end bracket the measured number.
By their numbers in this assay, from the lowest: compounds 1, 2, 4 and 3 (each within the scatter of the next, the first and the last beyond it).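

Lengthening propyl to pentyl on the acrylate ester gives a 1.1-fold lower number from compound 3 to compound 4 (0.04 log units; within the scatter) in this assay, so adding ethyl at this chain carbon does not separate the two compounds. With the pentyl chain kept, placing (vinylcarbonyl)oxy on the aromatic carbon instead of vinylcarbonyl gives a 1.6-fold higher number from compound 2 to compound 4 (0.22 log units; within the scatter), so the ester and the ketone cannot be told apart here either. No supporting data explain these results. Still open, as far as these compounds go, is whether an octyl chain would shift the number, or whether an amide in place of the ester would.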